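The source may hold more compounds than are shown below. What is called first, only, known or untested is meant among the compounds shown, and "the series" means these compounds.

Compound 1 `COc1ccc2ncc(S(=O)(=O)c3ccc(C)c(Cl)c3)c(N3CCC(C)CC3)c2c1` gives 85% in an assay on isolated protein for displacement of a labelled ligand from metabotropic glutamate receptor 5 (Homo sapiens), with a stated time of 60 min, tested at 1 uM; a higher number here means more inhibition at the concentration tested (going by the name of the read-out), a lower number less inhibition. That is the higher of the two numbers measured here; compound 2 `CCN1CCN(c2c(S(=O)(=O)c3ccccc3)cnc3ccccc23)CC1` gives 1.7% in this assay, a gap far beyond the usual scatter. Those two compounds differ in several places at once, so no single change can be read from that gap, though it does show that compounds of this kind can span nearly the whole range of the read-out. Compound 3 `COc1ccc2ncc(S(=O)(=O)c3ccc(F)cc3)c(N3CCC(C)CC3)c2c1` differs from compound 1 in one place only: 4-fluorophenyl in place of 3-chloro-4-methylphenyl on a sulfonyl sulfur. Nothing measured here isolates what this change does, so the expectation rests on the general picture alone. The step expected is a number 30 percentage points lower from compound 1 to compound 3 (beyond the scatter), a moderate loss of inhibition rather than a gain, and a wide range has to be allowed. Compound 3 is estimated at 55%, within a range from 20% to 85%.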

Compound 3, a percentage reported as inhibition, at one concentration (the size of the read-out at that concentration, not a potency): 27%
Beside the measured number, compound 3's estimate is 28 percentage points above it; the measured number falls inside the stated range.
By their numbers in this assay, from the lowest: compound 2; then compound 3; then compound 1.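

With the rest of the molecule unchanged, putting 4-fluorophenyl in place of 3-chloro-4-methylphenyl on a sulfonyl sulfur gives a number 58 percentage points lower from compound 1 to compound 3 (beyond the scatter) in this assay and counts as a large step. The group on the sulfonyl sulfur can therefore alter inhibition strongly by itself, something the comparison of compound 1 and compound 2 could not reveal because they differ in several places. No measurement shown here explains this loss of inhibition.

From the compounds shown here alone, this single change removes both chlorine and methyl and adds fluorine, so it remains open which of these matters, and a 3-chlorophenyl or a 4-methylphenyl group at this place would help separate them. Also open, going by these compounds, is whether a step of this size would recur on a different core.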